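Quaternary ammonium tail variants on the shared core

The source may report more compounds than this note shows. Statements on the series, on what has been measured and on what is new or still open speak of the compounds shown alone.

Compound 3 `Cc1cc(OCCCCCCC[N+]2(C)CCCCC2)cc(-n2cc(C(=O)Nc3cc(F)cc(F)c3)c(=O)c3ccc(N(C)C)nc32)c1` holds the highest value of the three measured compounds: in an assay on LX2 cells for inhibition of COL1A1 promoter (Homo sapiens), read by a luciferase reporter, with a stated time of 24 h, tested at 50 uM (a lower number here means a weaker effect, a higher number a stronger effect of the compound at the concentration tested), compound 3 gives 79.7%. Compound 2 `Cc1cc(OCCCCCCC[N+]2(C)CCCC2)cc(-n2cc(C(=O)Nc3cc(F)cc(F)c3)c(=O)c3ccc(N(C)C)nc32)c1` gives 35.4%, and compound 1 `Cc1cc(OCCCCCCC[N+]23CCN(CC2)CC3)cc(-n2cc(C(=O)Nc3cc(F)cc(F)c3)c(=O)c3ccc(N(C)C)nc32)c1` gives 5.52%. The measured steps are a number 29.9 percentage points higher from compound 1 to compound 2 (beyond the scatter), a number 74.2 percentage points higher from compound 1 to compound 3 (beyond the scatter) and a number 44.3 percentage points higher from compound 2 to compound 3 (beyond the scatter); all three exchange the whole charged ring group on the saturated chain carbon seven bonds along the chain from the oxygen on the aromatic ring.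

Compound 4 `CC[N+]1(CCCCCCCOc2cc(C)cc(-n3cc(C(=O)Nc4cc(F)cc(F)c4)c(=O)c4ccc(N(C)C)nc43)c2)CCCCC1` differs from compound 3 by methyl in place of hydrogen on a saturated chain carbon bound to an amine nitrogen in a ring. Among the compounds with values here, no measured step exchanges only a substituent on the charged nitrogen while keeping the ring; the measured steps therefore bear on this change only loosely, showing that the charged group's size matters for this series but not how a single added carbon on it acts. Given the small size of the change, compound 4 is expected to stay near compound 3, with an expected step of a number 4.7 percentage points lower from compound 3 to compound 4 (within the scatter), within the scatter. The estimate for compound 4 is 75%, ranging from 50% to 95%.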

Compound 4, a percentage reported as inhibition, at one concentration (the size of the read-out at that concentration, not a potency): 86.6%
Estimate against measurement, compound 4: 11.6 percentage points below; measured number inside the range.
By their numbers in this assay, from the lowest: compound 1; then compound 2; then compounds 3 and 4 (each within the scatter of the next).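

In this assay, within the data shown here, methyl in place of hydrogen on a saturated chain carbon bound to an amine nitrogen in a ring, which is the methyl to ethyl change, gives a number 6.9 percentage points higher from compound 3 to compound 4 (within the scatter); this is the first measured change that keeps the ring, and the two compounds cannot be told apart. The steps from the other ring groups remain large, with a number 51.2 percentage points higher from compound 2 to compound 4 (beyond the scatter) and a number 81.1 percentage points higher from compound 1 to compound 4 (beyond the scatter), so in these four compounds the large differences go with exchange of the whole ring group, not with this added carbon. No supporting data are at hand to account for these results.

Open, as far as these compounds go, is whether a propyl or benzyl group at this place holds the read-out at the level of compound 3 and compound 4. Also open, from the compounds shown here alone, is whether ethyl in place of methyl on the five-membered ring of compound 2 acts as it does on the six-membered ring.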